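The compounds below may be only part of what the source reports. "The series", "measured", "known", "first", "only" and "open" are said of these compounds alone.

Working notes on the series.

Compound 1 `Clc1ccc(OCc2nc3ccccc3n2CCCC2CCNCC2)cc1` and compound 2 `Clc1ccc(OCc2nc3ccccc3n2CCCC2CCCNC2)cc1` share the same core and differ only in the saturated ring at the end of the chain. In an assay on isolated protein for binding affinity to Neuropeptide Y receptor type 1 (Homo sapiens) (on this read-out higher numbers stand for weaker inhibition and lower numbers for stronger inhibition), compound 1 gives 980 nM and compound 2 gives 700 nM. Within the data shown here, the one step available, a 1.4-fold lower number from compound 1 to compound 2 (0.15 log units; within the scatter), stays inside the scatter, so on this assay the two compounds are not separable, and compound 2 carries the lowest of the two numbers recorded without that meaning a real difference.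

Compound 3 `Clc1ccc(OCc2nc3ccccc3n2CCC2CCCCN2)cc1` is the next point. The change from compound 2 is piperidin-2-yl in place of (piperidin-3-yl)methyl on a saturated chain carbon, two bonds along the chain from an aromatic nitrogen. This both shortens the chain to the saturated ring and moves the ring nitrogen to a new position relative to the chain.

Among the measured compounds shown here, only the step from compound 1 to compound 2 bears on it, and that step is within the scatter, so moving the ring nitrogen has so far left the number unchanged. Shortening the chain has no precedent in the series. The expectation for compound 3 in this assay is therefore a step of a 1.3-fold higher number from compound 2 to compound 3 (0.11 log units; within the scatter), not beyond the scatter. Compound 3 is estimated at 900 nM, with a range from 300 nM to 3000 nM.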

Compound 3, inhibition constant: 7860 nM
The estimate for compound 3 lay 8.7-fold (0.94 log units) below the measured number; measured number outside the range, above it.
By their numbers in this assay, from the lowest: compounds 2 and 1 (each within the scatter of the next); then compound 3.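

In this assay the end of the chain proves sensitive to change: piperidin-2-yl on the saturated chain carbon, two bonds along the chain from an aromatic nitrogen, gives an 11-fold higher number from compound 2 to compound 3 (1.05 log units; beyond the scatter) and an 8.0-fold higher number from compound 1 to compound 3 (0.90 log units; beyond the scatter) on the same core. Among these compounds, the earlier exchange of piperidin-4-yl for piperidin-3-yl stayed within the scatter, so these two steps are the first sign that the read-out responds to the chain and ring at this position, though the change shortens the chain and moves the ring nitrogen at once, and the steps cannot be divided between those two parts. No measurement at hand speaks to why the number rises with this change.

The compounds shown leave open whether chain length, the place of the ring nitrogen or the two together carry the step. A 3-(piperidin-2-yl)propyl group or a 2-(piperidin-3-yl)ethyl group on the same aromatic nitrogen would separate them, as each keeps one part of the change and reverts the other.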